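The compounds below may be only part of what the source reports. "The series", "measured", "known", "first", "only" and "open" are said of these compounds alone.

Compound 1 `O=c1oc2c(O)cccc2cc1-c1ccccc1` gives > 30000 nM
Compound 2 `O=c1oc2c(O)c(O)ccc2cc1-c1ccccc1` gives > 30000 nM
Compound 3 `O=c1oc2c(O)cccc2cc1-c1ccc(O)c(O)c1` gives > 30000 nM

The three measured compounds were all tested in a functional assay on CHO cells for antagonist activity at adenosine receptor A2b (Homo sapiens), read by cAMP accumulation; a lower number here means a stronger inhibitor, a higher number a weaker inhibitor. In this assay compound 1 gives > 30000 nM, which is a limit of the assay and not a number. Compound 2 likewise gives only a limit, > 30000 nM. Compound 3 also gives only a limit, > 30000 nM. All three therefore sit at the limit of > 30000 nM in this assay, at which 3 of the 3 values shown sit, and no one of them can be called stronger or weaker than another.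

Compound 2 differs from compound 1 by hydroxy in place of hydrogen on an aromatic carbon. The resulting step that the two limits leave unreadable from compound 1 to compound 2 cannot be sized because both values sit at the limit of > 30000 nM in this assay, at which 3 of the 3 values shown sit. The difference between the cores of compound 1 and compound 3 is not broken down here.

Compound 4 `O=c1oc2c(O)c(O)ccc2cc1-c1ccc(O)c(O)c1` has not yet been measured. Among the measured compounds shown here, it differs from compound 3 by hydroxy in place of hydrogen on an aromatic carbon, the same change as the one from compound 1 to compound 2. Since that earlier step gave no readable size, and since compound 3 itself sits at the limit of > 30000 nM in this assay, at which 3 of the 3 values shown sit, the expectation for compound 4 rests only on the weakness shown by all three measured compounds. Compound 4 is therefore expected to sit at or beyond the same limit in this assay, with an estimated value around 40000 nM, plausibly between 10000 nM and 150000 nM, corresponding to an expected step that the limit leaves unreadable from compound 3 to compound 4.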

Compound 4, half-maximal inhibitory concentration: > 30000 nM
Compound 4: only a limit was reported; the forecaster's own chance of this, stated with the estimate: 85%; the middle value is on the limit's open side.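

In this assay compound 4 gives > 30000 nM, which is a limit of the assay and not a number. Among the compounds shown here, compound 3 also has only a limit, so no step from compound 3 to compound 4 can be read, and all the compounds stand at the same place: the limit of > 30000 nM in this assay, at which 4 of the 4 values shown sit. The compounds shown leave open how weak each one truly is and whether the added hydroxy changes anything in this assay.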